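Swapping bromo for iodo on the shared core

The source may report more compounds than this note shows. Statements on the series, on what has been measured and on what is new or still open speak of the compounds shown alone.

The shared core is seen in compound 1 `Cc1cc(C)c2nc(CSc3ncccn3)[nH]c(=O)c2c1`. In an assay for inhibition of protein mono-ADP-ribosyltransferase PARP4 (Homo sapiens), read by chemiluminescence, with stated times of 10 min and 60 min (a lower number here means a stronger inhibitor, a higher number a weaker inhibitor), compound 1 gives 500 nM. Compound 2 `Cc1cc(Br)cc2c(=O)[nH]c(CSc3ncccn3)nc12` carries bromo in place of methyl on an aromatic carbon, and in this assay compound 2 gives 800 nM. The step of a 1.6-fold higher number from compound 1 to compound 2 (0.20 log units; within the scatter) lies within the scatter. Among the two numbers measured, compound 2 stands nearest compound 1, and no measured step separates them beyond the scatter.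

Compound 3 `Cc1cc(I)cc2c(=O)[nH]c(CSc3ncccn3)nc12` differs from compound 2 only by iodo in place of bromo on an aromatic carbon. For the measured compounds named here, the one measured step that bears on this place, the exchange from compound 1 to compound 2, a 1.6-fold higher number from compound 1 to compound 2 (0.20 log units; within the scatter), stayed within the scatter, so a further exchange of one halogen for another at the same carbon is expected to give no step beyond the scatter either. The expected step is no change at the digits printed from compound 2 to compound 3 (within the scatter). Compound 3 is therefore estimated at 800 nM, with a range from 400 nM to 1600 nM.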

Compound 3, half-maximal inhibitory concentration: 2700 nM
Beside the measured number, compound 3's estimate is 3.4-fold (0.53 log units) below it; measured number outside the range, above it.
By their numbers in this assay, from the lowest: compounds 1 and 2 (each within the scatter of the next); then compound 3.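

At this aromatic carbon the choice of group does matter in this assay: iodo in place of bromo gives a 3.4-fold higher number from compound 2 to compound 3 (0.53 log units; beyond the scatter) and so crosses the scatter, which the earlier exchange did not. Iodo in place of methyl gives a 5.4-fold higher number from compound 1 to compound 3 (0.73 log units; beyond the scatter), so compound 3 is the weakest inhibitor of the three, while methyl and bromo remain indistinguishable and halogens cannot be treated as interchangeable here. No measurement shown accounts for the weaker reading of the iodo compound.

The three compounds leave open how chloro, fluoro, an amine or a carboxylic acid would read at this same carbon. They also leave open whether iodo would give a similar step if the methyl group elsewhere on the shared core were replaced by a methoxy group.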